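Fluoro in place of methoxy, from compound 2 to compound 3

The compounds below may be only part of what the source reports. "The series", "measured", "known", "first", "only" and "open" are said of these compounds alone.

Compound 2 `CCC1=C(O)c2c(oc(-c3ccc(OC)c(OC)c3)cc2=O)C(CC)(CC)C1=O` gives 1 uM in a functional assay on KBVIN cells (Homo sapiens) for antiproliferative activity, read by sulforhodamine B assay, with a stated time of 3 days; on this read-out lower numbers stand for an effect already at smaller amounts and higher numbers for an effect only at larger amounts of compound. Among the compounds with values here, compound 1 `CCC1=C(O)c2c(oc(-c3ccccc3F)cc2=O)C(CC)(CC)C1=O` gives 3.93 uM in the same read-out, so compound 2 holds the lower of the two numbers so far, and the gap between them lies beyond the scatter. Compound 3 `CCC1=C(O)c2c(oc(-c3ccc(OC)c(F)c3)cc2=O)C(CC)(CC)C1=O` keeps the shared core and differs in one place: fluoro in place of methoxy on an aromatic carbon. Within the data shown here, no measured pair isolates this change. Among the measured compounds shown here, the only measured compound carrying fluoro is compound 1 at 3.93 uM and it offers a weak hint upward. Expected in this assay is a rise in the number (estimated step a 2.0-fold higher number from compound 2 to compound 3 (0.30 log units; within the scatter)) of a size near the edge of the scatter. For compound 3 the estimate is 2 uM (expected range 0.8 uM to 5 uM).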

Compound 3, concentration for half-maximal effect: 0.1 uM
Compound 3: middle estimate off by 20-fold (1.30 log units), on the high side; the whole stated range lies above it.
By their numbers in this assay, from the lowest: compound 3; then compound 2; then compound 1.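

Within the data shown here, this is the first measured pair to isolate the change: in this assay, fluoro in place of methoxy, on the aromatic carbon ortho to a methoxy group and meta to a large group, gives a 10-fold lower number from compound 2 to compound 3 (1.00 log units; beyond the scatter). Fluoro does not raise the number at this position, and the weak upward hint from compound 1 does not carry over; 3-fluoro-4-methoxyphenyl in place of 2-fluorophenyl gives a 39-fold lower number from compound 1 to compound 3 (1.59 log units; beyond the scatter). No available measurement accounts for the size of these steps.

Open, as far as these compounds go, is whether the drop belongs to fluoro itself or would also appear with chloro or hydroxy on this carbon. Also open, from the compounds shown here alone, is whether the remaining methoxy is needed.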